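Swapping One Five-Membered Ring for Another in the Rat

The source may report more compounds than this note shows. Statements on the series, on what has been measured and on what is new or still open speak of the compounds shown alone.

Compound 2 `CCc1c(OC)nc2nc(-c3nc(C)c(C)s3)cn2c1C` was tested in a functional assay on the whole organism with Rattus norvegicus as the target; on this read-out lower numbers stand for an effect already at smaller amounts and higher numbers for an effect only at larger amounts of compound. In this assay compound 2 gives > 50 mg/kg, which is a limit of the assay rather than a measured number. Compound 1 `CCc1c(OC)nc2nc(-c3nnco3)cn2c1C` shows the same picture: in this assay compound 1 gives > 50 mg/kg, again a limit. Going by the values given here, the only measured step, a step that the two limits leave unreadable from compound 1 to compound 2, therefore cannot be read, because of the limit of > 50 mg/kg in this assay, at which 2 of the 2 values shown sit. Compound 3 `CCc1c(OC)nc2nc(-c3nc(C)no3)cn2c1C` differs from compound 2 in one place: 3-methyl-1,2,4-oxadiazol-5-yl in place of 4,5-dimethyl-1,3-thiazol-2-yl on an aromatic carbon. Among the compounds with values here, no measured step bears on this change with a readable size, so any expectation rests only on where compound 2 stands. Compound 3 is therefore expected to remain at the limit as well, and the expected step that the limit leaves unreadable from compound 2 to compound 3 carries little weight. The estimate for compound 3 is 100 mg/kg, with an expected range from 20 mg/kg to 500 mg/kg.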

Compound 3, minimum effective dose: 5 mg/kg
The estimate for compound 3 lay 20-fold (1.30 log units) above the measured number; the whole stated range lies above it.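

This position, on an aromatic carbon of a five-membered aromatic ring with 2 nitrogen, is not indifferent to the ring it carries: in this assay, 3-methyl-1,2,4-oxadiazol-5-yl in place of 4,5-dimethyl-1,3-thiazol-2-yl gives an at least 10-fold lower number from compound 2 to compound 3 (1.00 log units; beyond the scatter). The same group in place of 1,3,4-oxadiazol-2-yl gives an at least 10-fold lower number from compound 1 to compound 3 (1.00 log units; beyond the scatter), so the word oxadiazole alone does not decide the outcome, since both of these groups carry that name. Both steps are minimum sizes and their true sizes remain unknown, because each starts from a limit rather than a number: the limit of > 50 mg/kg in this assay, at which 2 of the 3 values shown sit.

The entering group differs from 1,3,4-oxadiazol-2-yl both in how its ring atoms are arranged and in its methyl, and the compounds shown do not separate these two changes. On these data alone, how a longer chain such as ethyl in place of that methyl, or an amine in its place, would read in this assay stays open.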